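Opening a Cyclic Amide: Piperidine to Two Cyclopropylmethyl Arms

The source may report more compounds than this note shows. Statements on the series, on what has been measured and on what is new or still open speak of the compounds shown alone.

Measured compounds:
- compound 1, `O=C(O)c1cnn(-c2cccc(-c3cccc(C(=O)N4CCCCC4)c3F)c2)c1C1CC1`: 2300 nM
- compound 2, `CCCC1CCCCN1C(=O)c1cccc(-c2cccc(-n3ncc(C(=O)O)c3C3CC3c3ccccn3)c2)c1`: 3800 nM

Of the compounds shown here, two have numbers so far in an assay on BEAS-2B cells for activation of nuclear factor erythroid 2-related factor 2 (Homo sapiens), read by MTT assay, with a stated time of 48 h; a higher number here means that more compound is needed for the effect, a lower number that less compound is needed. Compound 1 gives 2300 nM and compound 2 gives 3800 nM. Going by the values given here, these two values lie within the usual scatter of each other, so neither can be called the more active of the pair; they differ in several places at once, and no single step connects them. Compound 1 simply holds the lower of the two numbers.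

The next compound, compound 3, `O=C(O)c1cnn(-c2cccc(-c3cccc(C(=O)N(CC4CC4)CC4CC4)c3F)c2)c1C1CC1`, changes compound 1 in one place: bis(cyclopropylmethyl)amino in place of piperidin-1-yl on a carbonyl carbon. The acid, the cyclopropyl group and the shared core stay the same. Among the compounds with values here, no measured pair shows what happens when this amide nitrogen is opened into two cyclopropylmethyl arms, so the size of the step cannot be read from the data. The expectation is therefore a step from compound 1 to compound 3 of a 1.1-fold higher number from compound 1 to compound 3 (0.04 log units; within the scatter) in this assay, not beyond the scatter in either direction. On that basis compound 3 is estimated at 2500 nM, with a likely range from 1000 nM to 6500 nM.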

Compound 3, half-maximal effective concentration in the nuclear factor erythroid 2-related factor 2 assay: 3500 nM
Beside the measured number, compound 3's estimate is 1.4-fold (0.15 log units) below it; low and high end bracket the measured number.
By their numbers in the nuclear factor erythroid 2-related factor 2 assay, from the lowest: compounds 1, 3 and 2 (each within the scatter of the next).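

In the nuclear factor erythroid 2-related factor 2 assay, the piperidin-1-yl group on the carbonyl carbon can be replaced by the larger, ring-opened bis(cyclopropylmethyl)amino group with a 1.5-fold higher number from compound 1 to compound 3 (0.18 log units; within the scatter), so the two compounds cannot be told apart on this read-out. Going by these compounds alone, this is the first single-place comparison at this position, and the same swap has a clear effect on a different property: in a physicochemical assay for lipophilicity, read by HPLC, at pH 2 (on this read-out higher numbers stand for higher lipophilicity and lower numbers for lower lipophilicity), it gives a number 1.20 log units higher from compound 1 to compound 3 (beyond the scatter), a large step. In the physicochemical assay compound 1 gives 2.3 and compound 3 gives 3.5. Lipophilicity therefore responds strongly to this change of amide group, while the higher measured value brings no lower number in the nuclear factor erythroid 2-related factor 2 assay: the measured distribution coefficient of compound 1, 2.3, and of compound 3, 3.5, a number 1.20 log units higher (beyond the scatter)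

The compounds shown leave open whether morpholin-4-yl, which puts an oxygen atom into the six-membered ring, or dimethylamino, with two methyl arms, would hold the number in the nuclear factor erythroid 2-related factor 2 assay while bringing the distribution coefficient back down. They also leave open whether any group on this carbonyl carbon can move the number in the nuclear factor erythroid 2-related factor 2 assay beyond the scatter at all.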